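A few compounds are considered here, and "the series" means these few. Any claim that something is new, unique, unknown or untested is made for them only; others in the source may bear on it.

Working notes on three aryl variants of one shared core, read in a functional assay on B16 cells (Mus musculus) for cytotoxicity, read by CCK-8 assay, with a stated time of 24 h; on this read-out higher numbers stand for weaker inhibition and lower numbers for stronger inhibition. Compound 1 `COc1ccccc1Oc1c(N)nc(-c2ccc(C)cc2)nc1OCCO` gives 8430 nM, compound 2 `COc1ccccc1Oc1c(N)nc(-c2ccc(F)cc2)nc1OCCO` gives 30100 nM, and compound 3 `COc1ccccc1Oc1c(N)nc(-c2ccc(Cl)cc2)nc1OCCO` gives 7740 nM.

Compound 3 sits at the low end of this small set, but it is not separated from its nearest neighbour: a 1.1-fold lower number from compound 1 to compound 3 (0.04 log units; within the scatter). Only the fluoro variant stands apart, as two steps show: a 3.6-fold higher number from compound 1 to compound 2 (0.55 log units; beyond the scatter) and a 3.9-fold lower number from compound 2 to compound 3 (0.59 log units; beyond the scatter).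

Among the measured compounds shown here, compound 4 `COc1ccccc1Oc1c(N)nc(-c2ccc(I)cc2)nc1OCCO` has no measurement yet. The change is iodo in place of chloro on an aromatic carbon, para to a large group.

For the measured compounds named here, no measured step involves iodo, so the evidence is indirect. Replacing methyl with chloro moved the number within the scatter, whereas the two modest steps both involve compound 2. The three compounds therefore show no smooth trend across these groups, and compound 2 goes against any flat reading.

For compound 4, no step beyond the scatter is expected in this assay, with more room allowed toward a higher number than a lower one. The expected move is a 1.0-fold higher number from compound 3 to compound 4 (0.01 log units; within the scatter). Compound 4 is estimated at 8000 nM, with an expected range of 3000 nM to 22000 nM.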

Compound 4, half-maximal inhibitory concentration: 19600 nM
The estimate for compound 4 lay 2.5-fold (0.39 log units) below the measured number, within the range that was stated.
By their numbers in this assay, from the lowest: compounds 3 and 1 (each within the scatter of the next); then compounds 4 and 2 (each within the scatter of the next).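

Replacing chloro with iodo at this position, on an aromatic carbon para to a large group, is not a neutral swap in this assay (a 2.5-fold higher number from compound 3 to compound 4 (0.40 log units; beyond the scatter)), and the iodo variant also separates from the methyl variant (a 2.3-fold higher number from compound 1 to compound 4 (0.37 log units; beyond the scatter)), so the closeness of methyl and chloro does not extend to iodo. Fluoro no longer stands alone at the high end, since compound 4 is not separated from compound 2 (a 1.5-fold lower number from compound 2 to compound 4 (0.19 log units; within the scatter)), and the four compounds fall into a methyl and chloro pair and a fluoro and iodo pair, with no steady trend from fluoro through chloro to iodo: compound 3 goes against one. No measurement at hand explains why these groups pair this way.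

Still open, from the compounds shown here alone, is where bromo would fall at this position, with the chloro and methyl pair or with the fluoro and iodo pair. Also open, going by these compounds, is how a non-halogen group such as an amine, a methoxy or a carboxylic acid on the same aromatic carbon would read, and whether the pairing holds on any other core or cell line.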